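Chloro for Methoxy: an Estimate for Compound 4

The source may hold more compounds than are shown below. What is called first, only, known or untested is meant among the compounds shown, and "the series" means these compounds.

Measured so far:
Compound 1, `Fc1ccc(-c2n[nH]cc2N2CCCNCC2)cc1`, gives 2190 nM in an assay on isolated protein for binding affinity to 5-hydroxytryptamine receptor 1D (Homo sapiens); on this read-out lower numbers stand for stronger inhibition and higher numbers for weaker inhibition.
Compound 2, `COc1cccc(-c2n[nH]cc2N2CCNCC2)c1`, gives > 10000 nM, which is a limit of the assay and not a number.
Compound 3, `COc1ccc(-c2n[nH]cc2N2CCNCC2)cc1`, gives > 10000 nM, again a limit of the assay.

Compound 2 therefore stands at the limit of this assay, and how far beyond it the compound lies is not known. Compound 3 sits at the same limit, and only compound 1 gives a number. Compound 4, `Clc1cccc(-c2n[nH]cc2N2CCNCC2)c1`, differs from compound 2 by chloro in place of methoxy on an aromatic carbon. No step between two measured compounds has been recorded, so the size of this change in this assay cannot be read from any pair shown. Two of the three values sit at the limit of > 10000 nM in this assay, at which 2 of the 3 values shown sit, and compound 2 is one of them, so even a clear gain would be expected to bring compound 4 only toward the range of compound 1. On that basis compound 4 is estimated at 6000 nM, with a range from 1500 nM to 20000 nM. The change this estimate implies, an at least 1.6-fold lower number from compound 2 to compound 4 (0.22 log units; that floor lies within the scatter), is expected to be a gain in affinity beyond the usual scatter, though a second limit remains a real possibility.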

Compound 4, inhibition constant: > 10000 nM
Compound 4: a limit, no number (the forecaster's own chance of this, stated with the estimate: 45%); middle value at least 1.6-fold (0.22 log units) from the limit.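

In this assay compound 4 gives > 10000 nM, a limit of the assay and not a number. For the compounds shown here, compound 2 gives a limit as well, so no step between compound 2 and compound 4 can be read: the limit of > 10000 nM in this assay, at which 3 of the 4 values shown sit. The compounds shown leave open how far past that limit each of the two lies, and whether chloro in place of methoxy changes the read-out at all.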